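Bromo for Methyl on the Aryl Ring of Compound 2

The compounds below may be only part of what the source reports. "The series", "measured", "known", "first", "only" and "open" are said of these compounds alone.

Measured compounds:
compound 1, `CC(=O)c1c(NNc2nc(C)cc(C)n2)cc(C)oc1=O`, 55.6%
compound 2, `Cc1ccc(-n2nc3cc(C)oc(=O)c3c2C)cc1`, 54%

Of the compounds shown here, two have been measured in a functional assay on the whole organism for inhibition, with Rattus norvegicus as the target, read by paw edema, with a stated time of 3 h, at a dose of 50 mg/kg; on this read-out higher numbers stand for more inhibition at the one dose given (going by the name of the read-out) and lower numbers for less inhibition. Compound 1 gives 55.6% and compound 2 gives 54%, so compound 2 stands lowest of the two numbers, yet its nearest neighbour, compound 1, lies within the scatter of it, and the two cannot be told apart on this read-out.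

The next compound, compound 3, `Cc1cc2nn(-c3ccc(Br)cc3)c(C)c2c(=O)o1`, differs from compound 2 in one place: bromo in place of methyl on an aromatic carbon. Among the measured compounds shown here, no step between measured compounds exists here, so there is no measured change to lean on. The account therefore expects no step beyond the scatter in this assay in either direction, and the estimate for compound 3 is 52%, with a range from 40% to 64%. The step this estimate means, a number 2 percentage points lower from compound 2 to compound 3 (within the scatter), is expected to stay within the scatter.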

Compound 3, a percentage reported as inhibition, in the whole organism at one dose (the size of the read-out at that dose, not a potency): 49.5%
Estimate against measurement, compound 3: 2.5 percentage points above, and the stated range covers the measured number.
By their numbers in this assay, from the lowest: compounds 3, 2 and 1 (each within the scatter of the next).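

In this assay, bromo in place of methyl on the aromatic carbon para to a large group gives a number 4.5 percentage points lower from compound 2 to compound 3 (within the scatter). Among the compounds shown here, this is the first step at this position, and it shows that this exchange on the aryl ring leaves the paw edema read-out unable to separate the two compounds at the one dose given. No measurement shown here offers an explanation for this result, and the step alone gives none.

The compounds shown leave open whether an amine, a carboxylic acid or a longer chain at this position would give a step beyond the scatter. They also leave open whether compound 2 and compound 3 would stay together at other doses or at other times.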